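One step from compound 2 to compound 3

This account rests on a few compounds, and the source may have more. Where it says the series, first, only, none or still open, it means among the compounds named here.

Compound 1 `O=C(Nc1ccc(C(F)(F)F)cc1)c1cccc(Nc2ncc(F)c(Nc3ccc(F)cc3)n2)c1`: > 10000 nM (a limit)
Compound 2 `O=C(c1cccc(Nc2ncc(F)c(Nc3ccc(F)cc3)n2)c1)N1CCCCC1`: 13000 nM

Both compounds were tested in a functional assay on DU-145 cells (Homo sapiens) for antiproliferative activity, read by sulforhodamine B assay, with a stated time of 3 days (a higher number here means a weaker inhibitor of growth, a lower number a stronger inhibitor of growth), and share one core. The entry for compound 1 is the limit of > 10000 nM in this assay, at which 1 of the 2 values shown sits, and is a limit of the assay, not a number. Going by the values given here, compound 2 therefore holds the only true number so far, 13000 nM, and cannot yet be ranked against compound 1.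

Compound 3 `COCC(=O)Nc1cccc(Nc2ncc(F)c(Nc3ccc(F)cc3)n2)c1` has not been measured. It carries ((methoxymethyl)carbonyl)amino in place of (piperidin-1-yl)carbonyl on an aromatic carbon. Among the compounds with values here, the only measured step is a step that the limit leaves unreadable from compound 1 to compound 2, so the data give no size or direction to carry over. No step beyond the scatter is therefore expected in this assay, though this expectation rests on very little. The expected change is a 1.2-fold lower number from compound 2 to compound 3 (0.07 log units; within the scatter). For compound 3 the estimate is 11000 nM, with an expected range from 4000 nM to 30000 nM.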

Compound 3, concentration for 50% growth inhibition: 4460 nM
The estimate for compound 3 lay 2.5-fold (0.39 log units) above the measured number; low and high end bracket the measured number.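

In this assay, going by these compounds alone, ((methoxymethyl)carbonyl)amino in place of (piperidin-1-yl)carbonyl gives a 2.9-fold lower number from compound 2 to compound 3 (0.46 log units; beyond the scatter) and is the first step with a readable size and direction. It shows that the number responds to the group held on this aromatic carbon, although the entering group differs from the leaving one at once in its lack of a ring and in its hydrogen-bond donor, and this single step cannot separate the two. Nothing measured for these compounds accounts for the step.

The entry for compound 1 is a limit of the assay, so its step to compound 2 cannot be read: the limit of > 10000 nM in this assay, at which 1 of the 3 values shown sits. As far as these compounds go, whether a longer chain or an amine on the same aromatic carbon would move the number further remains open.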